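Shortening the branched chain of compound 1 to propyl

A few compounds are considered here, and "the series" means these few. Any claim that something is new, unique, unknown or untested is made for them only; others in the source may bear on it.

Compound 1 `CC(/N=c1\c(O)c(O)\c1=N/c1cccnc1)C(C)(C)C`: 1950 nM
Compound 2 `COc1ncccc1/N=c1\c(O)c(O)\c1=N/C(C)(C)C`: 2560 nM
Compound 3 `CC(/N=c1\c(O)c(O)\c1=N/c1cncc(Br)c1)C(C)(C)C`: 11700 nM

All three values come from a functional assay for inhibition, with Rattus norvegicus as the target; on this read-out lower numbers stand for stronger inhibition and higher numbers for weaker inhibition. Among the measured compounds shown here, compound 1 at 1950 nM and compound 2 at 2560 nM lie within the scatter of each other, and no measured compound clearly beats compound 1 . Compound 3 stands apart, with a 6.0-fold higher number from compound 1 to compound 3 (0.78 log units; beyond the scatter) when bromo replaces hydrogen on an aromatic carbon.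

The next compound is compound 4 `CCC/N=c1\c(O)c(O)\c1=N/c1cccnc1`, and its change from compound 1 is propyl in place of 1,2,2-trimethylpropyl on a double-bonded nitrogen. For the measured compounds named here, no measured step touches this chain. Going by the values given here, the bromo step lies at another place, so it shows only that a single change can move the number beyond the scatter. Compound 2 also differs from compound 1 in more than one place, so it cannot isolate the chain's contribution.

Without direct evidence, only a small rise is expected, and this amounts to an estimated 1.8-fold higher number from compound 1 to compound 4 (0.25 log units; within the scatter). For compound 4 the expected value is 3500 nM, with an estimated range from 700 nM to 15000 nM.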

Compound 4, half-maximal inhibitory concentration: > 30000 nM
Compound 4: only a limit was reported (the forecaster's own chance of this, stated with the estimate: 5%); at least 8.5-fold (0.93 log units) between middle value and limit.
By their numbers in this assay, from the lowest: compounds 1 and 2 (each within the scatter of the next); then compound 3. At a limit, above all of these: compound 4.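

Among the compounds shown here, this is the first step that touches the chain on the double-bonded nitrogen, and it shows that this position matters: propyl in place of 1,2,2-trimethylpropyl gives an at least 15-fold higher number from compound 1 to compound 4 (1.18 log units; beyond the scatter). In this assay compound 4 gives > 30000 nM as its reading, and this is a limit, not a number. The step therefore marks only how large the rise must be, and its true size cannot be read: the limit of > 30000 nM in this assay, at which 1 of the 4 values shown sits.

Propyl is both shorter and unbranched, and the compounds shown do not separate these two features. An isobutyl chain or a cyclohexyl ring on the same nitrogen, with the rest of compound 1 unchanged, would help show how much of the original chain is needed.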